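Amino to nitro: what tolerance to expect for compound 4

The source may hold more compounds than are shown below. What is called first, only, known or untested is meant among the compounds shown, and "the series" means these compounds.

Of the compounds shown here, three sharing one core have been tested in an ADME assay on MDBK cells (Bos taurus) for cytotoxicity, read by MTT assay, with a stated time of 96 h; a higher number here means that more compound is tolerated, a lower number that less compound is tolerated. Compound 1 `COc1ccc(-c2nc3cc(Cl)c(Cl)cc3[nH]2)cc1` gives 2500 nM, compound 2 `Nc1ccc(-c2nc3cc(Cl)c(Cl)cc3[nH]2)cc1` gives 7500 nM, and compound 3 `O=C(CN1CCCC1)Nc1ccc(-c2nc3cc(Cl)c(Cl)cc3[nH]2)cc1` gives 16000 nM. Compound 2 thus stands second highest of the three, with compound 3 above it and compound 1 below it. Both measured steps were modest: a 3.0-fold higher number from compound 1 to compound 2 (0.48 log units; beyond the scatter) and a 2.1-fold higher number from compound 2 to compound 3 (0.33 log units; beyond the scatter). Compound 4 `O=[N+]([O-])c1ccc(-c2nc3cc(Cl)c(Cl)cc3[nH]2)cc1` differs from compound 2 by nitro in place of amino on an aromatic carbon. Going by the values given here, only the step from compound 1 to compound 2 also changed the group on the aromatic carbon para to a large group, and no measured step swaps amino for nitro, so the direction is uncertain and a modest step either way seems plausible. Compound 4 is expected to give 5000 nM in this assay, between 2000 nM and 15000 nM. That estimate would mean an expected step of a 1.5-fold lower number from compound 2 to compound 4 (0.18 log units; within the scatter).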

Compound 4, half-maximal cytotoxic concentration: 56000 nM
Estimate against measurement, compound 4: 11-fold (1.05 log units) below; the whole stated range lies below it.
By their numbers in this assay, from the lowest: compound 1; then compound 2; then compound 3; then compound 4.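

Going by these compounds alone, on the aromatic carbon para to a large group, the choice of group matters more in this assay than the earlier compounds showed. Nitro in place of amino gives a 7.5-fold higher number from compound 2 to compound 4 (0.87 log units; beyond the scatter) and nitro in place of methoxy gives a 22-fold higher number from compound 1 to compound 4 (1.35 log units; beyond the scatter), so this position can shift tolerance well beyond the modest steps seen before. Nothing available here explains why nitro stands apart. From the compounds shown here alone, whether a nitrile or a carboxylic acid at this position would give a similar number remains open. So does whether the same change would hold on a different core.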